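A few compounds are considered here, and "the series" means these few. Any claim that something is new, unique, unknown or untested is made for them only; others in the source may bear on it.

Compound 3 `CN(C)CCCNc1nc(-c2ccc(NC(=O)Nc3ccc(Cl)cc3)cc2)nc2c(Cl)c(Cl)sc12` gives the highest number of the three measured compounds in a functional assay on MKN-45 cells (Homo sapiens) for cytotoxicity, read by MTT assay, with a stated time of 72 h (a lower number here means a stronger inhibitor, a higher number a weaker inhibitor), at 1530 nM. Its nearest neighbour is compound 1 `CN(C)CCCNc1nc(-c2ccc(NC(=O)Nc3ccc(F)cc3)cc2)nc2c(Cl)c(Cl)sc12`, which gives 1120 nM in this assay; the step of a 1.4-fold higher number from compound 1 to compound 3 (0.14 log units; within the scatter) is a change of chloro in place of fluoro on an aromatic carbon. Furthest away stands compound 2 `CN(C)CCCNc1nc(-c2ccc(NC(=O)Nc3ccccc3Cl)cc2)nc2ccsc12`, which gives 690 nM in this assay, a number beyond the scatter below that of compound 3, though compound 2 differs from compound 3 in two places at once and no single step joins them.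

Compound 4 `CN(C)CCCNc1nc(-c2ccc(NC(=O)Nc3ccccc3Cl)cc2)nc2c(Cl)c(Cl)sc12` is the untested member of the group. It has the same atoms as compound 3, joined differently: 2-chlorophenyl in place of 4-chlorophenyl on an amide-type nitrogen. For the measured compounds named here, no measured step isolates this change. Going by the values given here, the only step on hand, from compound 1 to compound 3, concerns a different exchange and stayed within the scatter, so it says little about moving the chloro around the ring. Compound 2 carries the same 2-chlorophenyl group as compound 4, and its lower number hints, weakly, that compound 4 may come out below compound 3. Compound 4 is therefore expected to show a 1.5-fold lower number from compound 3 to compound 4 (0.18 log units; within the scatter) in this assay, a step not clearly beyond the scatter, and its estimated value is 1000 nM, within a range from 450 nM to 2300 nM.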

Compound 4, half-maximal inhibitory concentration: 1330 nM
The estimate for compound 4 lay 1.3-fold (0.12 log units) below the measured number; the range from low to high includes it.
By their numbers in this assay, from the lowest: compounds 2, 1, 4 and 3 (each within the scatter of the next, the first and the last beyond it).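

Within this assay, moving the chloro around the phenyl ring, from 4-chlorophenyl to 2-chlorophenyl on the amide-type nitrogen, gives a 1.2-fold lower number from compound 3 to compound 4 (0.06 log units; within the scatter) and so, for the first time here, the placement of the chloro is tested by itself, with a result inside the scatter. The same place read against the fluoro analogue gives a 1.2-fold higher number from compound 1 to compound 4 (0.07 log units; within the scatter) and this also stays within the scatter, so 4-fluorophenyl, 4-chlorophenyl and 2-chlorophenyl cannot be told apart at this position on the core shared by compound 1, compound 3 and compound 4. Nothing at hand offers an explanation for this result.

As far as these compounds go, all three of these groups are halogen-bearing phenyl groups, so it remains open whether a carboxylic acid, an amine or a methoxy group on that phenyl ring would move the number beyond the scatter. For the compounds shown here, also open is what the two chloro groups on the core contribute, since compound 2 gives 690 nM and compound 4 gives 1330 nM with the same 2-chlorophenyl group, and no step between these two is available to read.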